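Urotensin-2 receptor ureas: phenoxy for phenyl on the aryl urea

The source may hold more compounds than are shown below. What is called first, only, known or untested is meant among the compounds shown, and "the series" means these compounds.

Compound 3 `CN(C)CCC(NC(=O)Nc1ccc(-c2ccccc2)cc1)c1ccc(Cl)cc1` stands lowest of the three measured compounds in an assay on NIH3T3 cells with Urotensin-2 receptor (Homo sapiens) as the target (a higher number here means a larger maximal response, a lower number a smaller maximal response), giving 91%. Its nearest neighbour is compound 2 `CN(C)CCC(NC(=O)Nc1ccc(C(F)(F)F)cc1)c1ccc(Cl)cc1`, which gives 105%, and the furthest is compound 1 `COc1ccc(NC(=O)NC(CCN(C)C)c2ccc(Cl)cc2)cc1`, which gives 195%. The steps to compound 3 were a number 104 percentage points lower from compound 1 to compound 3 (beyond the scatter) and a number 14 percentage points lower from compound 2 to compound 3 (beyond the scatter), while a number 90 percentage points lower from compound 1 to compound 2 (beyond the scatter) separates the two other compounds.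

Compound 4 `CN(C)CCC(NC(=O)Nc1ccc(Oc2ccccc2)cc1)c1ccc(Cl)cc1` is now considered. It differs from compound 3 as follows: phenoxy in place of phenyl on an aromatic carbon. Among the compounds with values here, no measured step exchanges phenyl for phenoxy, so the bearing steps are indirect: compound 3 with phenyl sits below both compound 2 and compound 1, and the only substituent attached through oxygen, the methoxy of compound 1, goes with the largest response because compound 1 gives 195%. A moderate rise is therefore expected, of the order of a number 24 percentage points higher from compound 3 to compound 4 (beyond the scatter), but with a wide range, since the phenoxy group is also far bulkier than methoxy and the steps of compound 2 and compound 3 show large substituents near the bottom. Compound 4 is estimated at 115% in this assay, with a range from 75% to 170%.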

Compound 4, largest response reached (reported as efficacy), in percent of the reference or control that the assay uses: 108%
Compound 4: middle estimate off by 7 percentage points, on the high side; the measured number falls inside the stated range.
By their numbers in this assay, from the lowest: compound 3; then compounds 2 and 4 (each within the scatter of the next); then compound 1.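

In this assay, phenoxy in place of phenyl on this aromatic carbon, para to a large group, gives a number 17 percentage points higher from compound 3 to compound 4 (beyond the scatter), so adding an oxygen link before the terminal ring moves the response modestly upward. Phenoxy in place of trifluoromethyl gives a number 3 percentage points higher from compound 2 to compound 4 (within the scatter), while phenyl in place of the methyl on the oxygen gives a number 87 percentage points lower from compound 1 to compound 4 (beyond the scatter), so among these compounds the oxygen link alone does not bring the large response of compound 1, and the group on the oxygen matters. No measured evidence accounts for these steps.

Still open, on these data alone, is how the response runs between methoxy and phenoxy, for instance with ethoxy or benzyloxy on this carbon. Also open, as far as these compounds go, is whether an anilino group, with nitrogen as the link, tracks phenoxy or phenyl.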